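Removing a methoxy group from a thiazolyl-pyrimidine series

The compounds below may be only part of what the source reports. "The series", "measured", "known", "first", "only" and "open" are said of these compounds alone.

Compound 1 `Cc1nc(-c2ccccc2)sc1C(=O)CSc1nc(N)c(C#N)c(-c2ccccc2)n1`: 93%
Compound 2 `Cc1nc(-c2ccc(Cl)cc2)sc1C(=O)CSc1nc(N)c(C#N)c(-c2ccc(Cl)cc2)n1`: 37.3%
Compound 3 `COc1ccc(-c2nc(SCC(=O)c3sc(-c4ccc(Cl)cc4)nc3C)nc(N)c2C#N)cc1`: 64.5%

In a functional assay on U-87MG ATCC cells for antiproliferative activity against U-87 MG (Homo sapiens), read by MTT assay, with a stated time of 48 h, tested at 10 uM (a higher number here means a weaker effect of the compound at the concentration tested, a lower number a stronger effect), compound 3 stands second highest of the three numbers, nearer to compound 2 than to compound 1. Within the data shown here, the measured step of a number 27.2 percentage points higher from compound 2 to compound 3 (beyond the scatter) is the only step that changes the aryl group on the pyrimidine part of the shared core. Compound 4 `Cc1nc(-c2ccc(Cl)cc2)sc1C(=O)CSc1nc(N)c(C#N)c(-c2ccccc2)n1` keeps the chlorophenyl on the thiazole side and differs from compound 3 by hydrogen in place of methoxy on an aromatic carbon. Among the measured compounds shown here, no measured step covers hydrogen in place of methoxy at this place; compound 1 and compound 2 show that without any chloro the number is far higher. For compound 4 the step of a number 3.5 percentage points higher from compound 3 to compound 4 (within the scatter) is therefore expected to stay within the scatter. Compound 4 is estimated at 68%, in the range 48% to 88%.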

Compound 4, a percentage reported as activity, at one concentration (the size of the read-out at that concentration, not a potency): 67.9%
Compound 4: the middle estimate sits 0.1 percentage points above what was measured; low and high end bracket the measured number.
By their numbers in this assay, from the lowest: compound 2; then compounds 3 and 4 (each within the scatter of the next); then compound 1.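

In this assay, the change from 4-methoxyphenyl to phenyl gives a number 3.4 percentage points higher from compound 3 to compound 4 (within the scatter), so at this place methoxy and hydrogen cannot be told apart. Chloro does stand apart here: hydrogen in place of chloro gives a number 30.6 percentage points higher from compound 2 to compound 4 (beyond the scatter). On the other aromatic ring, with this place left as hydrogen, chloro in place of hydrogen gives a number 25.1 percentage points lower from compound 1 to compound 4 (beyond the scatter), so each of the two chloro groups counts on its own. From the compounds shown here alone, whether an amine or a carboxylic acid at this place would read like chloro or like hydrogen stays open. Nothing given here bears on why these numbers differ.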